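A few compounds are considered here, and "the series" means these few. Any claim that something is new, unique, unknown or untested is made for them only; others in the source may bear on it.

Measured so far:
compound 1 `CCN(C(=O)CN(c1cc(N(C)C)ccc1Cl)S(=O)(=O)c1ccc(OC)c(OC)c1)c1ccn(C)n1` — 12 nM
compound 2 `CCN(CC)C(=O)CN(c1ccc(C)cc1)S(=O)(=O)c1cccc(C)c1` — > 10000 nM

In a functional assay on CHO cells for inhibition of Orexin/Hypocretin receptor type 1 (Homo sapiens), read by FLIPR and calcium flux (on this read-out lower numbers stand for stronger inhibition and higher numbers for weaker inhibition), compound 1 gives 12 nM. Compound 2 gives only the limit of the assay, > 10000 nM, so no number stands for it; it sits at the limit of > 10000 nM in this assay, at which 1 of the 2 values shown sits. The two compounds differ in more than one place, so their gap is not a step; the two values only show one compound with a number and one without. Compound 3 `CCN(CC)C(=O)CN(c1ccc(C)cc1)S(=O)(=O)c1ccc(OC)cc1` is still to be measured in this assay. It differs from compound 2 by 4-methoxyphenyl in place of 3-methylphenyl on a sulfonyl sulfur. With compound 2 at a limit, the step can only be judged as none, or as a move downward from the limit. The expected step is a step that the limit leaves unreadable from compound 2 to compound 3, which amounts to no change beyond the scatter. For compound 3 the estimate in this assay is 15000 nM, within 3000 nM to 60000 nM, most likely again reported as a limit only.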

Compound 3, half-maximal inhibitory concentration: > 10000 nM
Compound 3 gave a limit, no number; the forecaster's own chance of this, stated with the estimate: 70%; the middle value is on the limit's open side.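

Compound 2 and compound 3 both stay at a limit in this assay, so no step can be read for 4-methoxyphenyl in place of 3-methylphenyl on a sulfonyl sulfur: the limit of > 10000 nM in this assay, at which 2 of the 3 values shown sit. The compounds shown leave open whether this exchange changes inhibition at all.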